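Aromatic nitrogen substituents: from compound 3 to compound 4

A few compounds are considered here, and "the series" means these few. Any claim that something is new, unique, unknown or untested is made for them only; others in the source may bear on it.

compound 1 `COc1cc(-c2ccnc3cc(-c4cn(CO)c5ccccc45)nn23)cc(OC)c1OC` gives 19 nM
compound 2 `COc1cc(-c2ccnc3cc(-c4c[nH]c5ccccc45)nn23)cc(OC)c1OC` gives 85 nM
compound 3 `COc1cc(-c2ccnc3cc(-c4cn(C)c5ccccc45)nn23)cc(OC)c1OC` gives 95 nM

All three values come from a functional assay on MCF7 cells (Homo sapiens) for inhibition, read by CCK-8 assay, with a stated time of 48 h (a lower number here means a stronger inhibitor, a higher number a weaker inhibitor), and compound 3 sits at the weak end of this small set. Its nearest neighbour offers no real gap, with a 1.1-fold higher number from compound 2 to compound 3 (0.05 log units; within the scatter) on record, while the furthest shows a 5.0-fold higher number from compound 1 to compound 3 (0.70 log units; beyond the scatter) as the clear separation.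

The next compound is compound 4 `COc1cc(-c2ccnc3cc(-c4cn(C(=O)OC(C)(C)C)c5ccccc45)nn23)cc(OC)c1OC` with tert-butoxycarbonyl in place of methyl on an aromatic nitrogen as the whole change. The steps at this same nitrogen are the guide. They run from a 1.1-fold higher number from compound 2 to compound 3 (0.05 log units; within the scatter) up to a 5.0-fold higher number from compound 1 to compound 3 (0.70 log units; beyond the scatter) and a 4.5-fold higher number from compound 1 to compound 2 (0.65 log units; beyond the scatter) so changes here have so far been modest at most. Among the compounds with values here, no measured compound carries a carbonyl at this nitrogen, so the direction stays open.

In this assay the expected move is a 1.4-fold higher number from compound 3 to compound 4 (0.14 log units; within the scatter) and this estimate carries a wide margin on either side. The estimated value for compound 4 is 130 nM (expected range 40 nM to 500 nM)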

Compound 4, half-maximal inhibitory concentration: 268 nM
The estimate for compound 4 lay 2.1-fold (0.31 log units) below the measured number; the measured number falls inside the stated range.
By their numbers in this assay, from the lowest: compound 1; then compounds 2 and 3 (each within the scatter of the next); then compound 4.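

In this assay, a carbonyl-bearing group at this aromatic nitrogen gives a higher number than the small substituents, as shown by a 2.8-fold higher number from compound 3 to compound 4 (0.45 log units; beyond the scatter) and by a 3.2-fold higher number from compound 2 to compound 4 (0.50 log units; beyond the scatter) in the same direction, although hydrogen and methyl themselves could not be separated. Within the data shown here, the widest gap at this nitrogen is now a 14-fold higher number from compound 1 to compound 4 (1.15 log units; beyond the scatter) and is the only large step, so the choice of substituent here can matter more than the earlier modest steps indicated. Among these compounds, compound 1 and compound 4 mark the two ends of the series so far, with hydroxymethyl at the low end and tert-butoxycarbonyl at the high end.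

On these data alone, whether hydroxyethyl or aminomethyl would keep the low number of compound 1, and whether acetyl would behave like tert-butoxycarbonyl, stays open. Nothing on hand accounts for these steps.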